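This account rests on a few compounds, and the source may have more. Where it says the series, first, only, none or still open, it means among the compounds named here.

Working notes on the triazole series. Compound 1 `C=CCn1c(SC/C(=N/O)c2ccccc2)nnc1-c1cc(OC)c(OC)c(OC)c1` gives 77% in a functional assay on the whole organism (strain albino) for inhibition, with Rattus norvegicus as the target, read by paw edema, with a stated time of 5 h, at a dose of 0.28 mmol/kg by the oral route; a higher number here means more inhibition at the dose given (going by the name of the read-out), a lower number less inhibition. Compound 2 `COc1cc(-c2nnc(SC/C(=N/O)c3ccccc3)n2-c2ccccc2)cc(OC)c1OC` gives 68% in this assay; the change from compound 1 is phenyl in place of allyl on an aromatic nitrogen, and the step is a number 9 percentage points lower from compound 1 to compound 2 (within the scatter). Compound 3 `C=CCn1c(SCC(=O)c2ccccc2)nnc1-c1cc(OC)c(OC)c(OC)c1` gives 60% in this assay; it differs from compound 1 by a group of 8 heavy atoms (7 carbon, 1 oxygen; one six-membered aromatic ring of carbon only) in place of a group of 9 heavy atoms (7 carbon, 1 nitrogen, 1 oxygen; one six-membered aromatic ring of carbon only), on a saturated chain carbon bound to a sulfur, and the step is a number 17 percentage points lower from compound 1 to compound 3 (beyond the scatter). Compound 4 `COc1cc(-c2nnc(SCC(=O)c3ccccc3)n2-c2ccccc2)cc(OC)c1OC` is not yet measured in this assay; it differs from compound 3 by phenyl in place of allyl on an aromatic nitrogen, the same kind of change as from compound 1 to compound 2, with the two cores differing as described under the change from compound 1 to compound 3. The surroundings differ in one respect: in compound 1 the aromatic nitrogen sits next to two ring atoms that each bear a large group, whereas in compound 3 it sits next to the ring atom that bears a (benzoylmethyl)sulfanyl group and next to the ring atom that bears a large group. The step from compound 3 to compound 4 is expected to be a number 8 percentage points lower from compound 3 to compound 4 (within the scatter), resting on the size of a number 9 percentage points lower from compound 1 to compound 2 (within the scatter), which lay within the scatter. For compound 4 the estimate is 52%, with a range from 40% to 65%.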

Compound 4, a percentage reported as inhibition, in the whole organism at one dose (the size of the read-out at that dose, not a potency): 72%
Estimate against measurement, compound 4: 20 percentage points below, outside the stated range (above it).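

In this assay, phenyl in place of allyl on an aromatic nitrogen does not carry over between the two cores; on the core of compound 3 the step is a number 12 percentage points higher from compound 3 to compound 4 (beyond the scatter), and it differs from the earlier step: the same change on two cores in this assay, a number 9 percentage points lower (within the scatter) from compound 1 to compound 2 and a number 12 percentage points higher (beyond the scatter) from compound 3 to compound 4, 21 percentage points apart, beyond the scatter of two such steps. The exchange on the saturated chain carbon bound to a sulfur likewise depends on the group on the aromatic nitrogen; with phenyl there, the step is a number 4 percentage points higher from compound 2 to compound 4 (within the scatter), and it differs from the earlier step with allyl: the same change on two cores in this assay, a number 17 percentage points lower (beyond the scatter) from compound 1 to compound 3 and a number 4 percentage points higher (within the scatter) from compound 2 to compound 4, 21 percentage points apart, beyond the scatter of two such steps. Across these four compounds, the two changes therefore do not add up, so a step read on one core does not predict the other, but the data do not show why and rest on one read-out at a single dose.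

On these data alone, it remains open whether a benzyl group or a longer alkyl chain on the aromatic nitrogen would follow allyl or phenyl. As far as these compounds go, it also remains open whether the same dependence holds when the group on the saturated chain carbon bound to a sulfur carries an amine or a carboxylic acid.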